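The source may report more compounds than this note shows. Statements on the series, on what has been measured and on what is new or still open speak of the compounds shown alone.

Compound 1 `Cc1ccc(Cn2cc(COc3ccc4c(=O)ccoc4c3)nn2)cc1` carries a 4-methylphenyl group on a saturated chain carbon bound to an aromatic nitrogen. In a functional assay on SW480 cells (Homo sapiens) for cytotoxicity, read by MTT assay, with a stated time of 48 h (a lower number here means a stronger inhibitor, a higher number a weaker inhibitor), compound 1 gives 10400 nM. Among the numbers shown here this is the only full value, since the other measured compound reached only a limit. That other compound, compound 2 `O=c1ccoc2cc(OCc3cn(Cc4ccc(Cl)cc4Cl)nn3)ccc12`, is reported in this assay only as a limit of > 100000 nM. Swapping the aryl group at this position gave an at least 9.6-fold higher number from compound 1 to compound 2 (0.98 log units; beyond the scatter). Compound 3 `O=c1ccoc2cc(OCc3cn(Cc4cccc([N+](=O)[O-])c4)nn3)ccc12` has not yet been measured; it differs from compound 1 in one place: 3-nitrophenyl in place of 4-methylphenyl on a saturated chain carbon bound to an aromatic nitrogen. Going by the values given here, the single step that bears on this change is the exchange of the same 4-methylphenyl for another aryl group, which produced an at least 9.6-fold higher number from compound 1 to compound 2 (0.98 log units; beyond the scatter) and ended at the limit of > 100000 nM in this assay, at which 1 of the 2 values shown sits. A different aryl group enters here, so the size of that step need not repeat, but a weakening beyond the scatter is the more likely expectation in this assay. The step expected from compound 1 to compound 3 is therefore a 2.4-fold higher number from compound 1 to compound 3 (0.38 log units; beyond the scatter). Compound 3 is estimated at 25000 nM, within a range from 6000 nM to 100000 nM.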

Compound 3, half-maximal inhibitory concentration: > 100000 nM
Compound 3 was reported as a limit (the forecaster's own chance of this, stated with the estimate: 35%); at least 4.0-fold (0.60 log units) between middle value and limit.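

In this assay, 3-nitrophenyl in place of 4-methylphenyl on a saturated chain carbon bound to an aromatic nitrogen gives an at least 9.6-fold higher number from compound 1 to compound 3 (0.98 log units; beyond the scatter), so the loss seen with 2,4-dichlorophenyl now appears with a second, differently substituted aryl group, and it is not confined to that one group. Compound 2 and compound 3 end at the same limit, which is a boundary of the assay and not a measured number: the limit of > 100000 nM in this assay, at which 2 of the 3 values shown sit. The step between compound 2 and compound 3 cannot be read from two limits, so no order can be stated for these two, and compound 1 remains the only one of the three with a full value.

Three compounds cannot show whether the 4-methylphenyl group of compound 1 is itself needed for a measurable value, or whether any aryl group carrying other substituents at this place falls away in the same manner. Also open, as far as these compounds go, is what a plain phenyl ring, a 4-chlorophenyl or 4-methoxyphenyl group, a ring bearing an amine or a carboxylic acid, or a simple alkyl chain would give here.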